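The source may report more compounds than this note shows. Statements on the series, on what has been measured and on what is new or still open speak of the compounds shown alone.

Of the compounds shown here, two share a core and have been tested in a physicochemical assay for solubility, read by LC-MS, in phosphate buffer, measured as thermodynamic solubility, with a stated time of 24 h, at pH 7.4; on this read-out lower numbers stand for lower solubility and higher numbers for higher solubility. Compound 1 `Cn1cc(-c2cnc3c(c2)c(-c2cccc(C#N)c2)cn3C)cn1` gives 3000 nM, while compound 2 `N#Cc1cccc(-c2n[nH]c3ncc(-c4cnn(C5CCOCC5)c4)cc23)c1` gives 700 nM, the lower of the two numbers, set apart from compound 1 by a gap beyond the scatter. Going by these compounds, compound 3 `Cc1c(-c2cnn(C3CCOCC3)c2)cnc2[nH]nc(-c3cccc(C#N)c3)c12` is untested; it differs from compound 2 by methyl in place of hydrogen on an aromatic carbon. For the measured compounds named here, no measured pair isolates such a change, so the expected step is small, likely downward but possibly within scatter. Compound 3 is expected to give 450 nM, in the range 150 nM to 1500 nM, a step of a 1.6-fold lower number from compound 2 to compound 3 (0.19 log units; within the scatter).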

Compound 3, solubility: 2000 nM
Compound 3: the middle estimate sits 4.4-fold (0.65 log units) below what was measured, outside the stated range (above it).
By their numbers in this assay, from the lowest: compound 2; then compounds 3 and 1 (each within the scatter of the next).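

In this assay, methyl in place of hydrogen on this aromatic carbon, ortho to a large group and opposite the ring nitrogen, gives (a 2.9-fold higher number from compound 2 to compound 3 (0.46 log units; beyond the scatter)). This is the only change in one place among these compounds, and it shows that a single added carbon at this position can raise the number beyond the scatter. Nothing available here accounts for the rise. Going by these compounds, whether an ethyl, a methoxy or an amine on the same carbon would move the number likewise stays open. So does whether methyl would have the same outcome elsewhere on the shared core.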